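Dichlorophenyl Swap on a Second Sulfonamide Core

A few compounds are considered here, and "the series" means these few. Any claim that something is new, unique, unknown or untested is made for them only; others in the source may bear on it.

Compound 1 `COc1ccc(Cl)cc1S(=O)(=O)Nc1ccc2oc(-c3ccccc3)nc2c1` and compound 3 `COc1ccc(Cl)cc1S(=O)(=O)Nc1ccc(-c2nc3ccccc3o2)cc1` are built from the same atoms joined differently; the difference between the two cores is not broken down here. In an ADME assay on HEK293 cells (Homo sapiens) for cytotoxicity, read by resazurin assay, with a stated time of 48 h (a lower number here means that less compound is tolerated, a higher number that more compound is tolerated), compound 1 gives 74000 nM, and compound 3 gives 75000 nM. Compound 2 `O=S(=O)(Nc1ccc2oc(-c3ccccc3)nc2c1)c1ccc(Cl)c(Cl)c1` carries 3,4-dichlorophenyl in place of 5-chloro-2-methoxyphenyl on a sulfonyl sulfur; the step was a 1.0-fold lower number from compound 1 to compound 2 (0.02 log units; within the scatter), and in this assay compound 2 gives 71000 nM. Compound 4 `O=S(=O)(Nc1ccc(-c2nc3ccccc3o2)cc1)c1ccc(Cl)c(Cl)c1` carries the same change on the core of compound 3, (3,4-dichlorophenyl in place of 5-chloro-2-methoxyphenyl on a sulfonyl sulfur), at a place described in the same words. Because a 1.0-fold lower number from compound 1 to compound 2 (0.02 log units; within the scatter) stayed within the scatter, the expected step is a 1.0-fold lower number from compound 3 to compound 4 (0.02 log units; within the scatter). Compound 4 is therefore estimated to give 72000 nM, with a likely range from 45000 nM to 115000 nM.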

Compound 4, half-maximal cytotoxic concentration: > 100000 nM
Compound 4: no number, only a limit (the forecaster's own chance of this, stated with the estimate: 10%); at least 1.3-fold (0.14 log units) between middle value and limit.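

In this assay compound 4 gives > 100000 nM, which is a limit of the assay and not a number. On the core of compound 3, putting 3,4-dichlorophenyl in place of 5-chloro-2-methoxyphenyl gives an at least 1.3-fold higher number from compound 3 to compound 4 (0.12 log units; that floor lies within the scatter), and set beside the same change on the core of compound 1, the comparison reads: the same change on two cores in this assay, a 1.0-fold lower number (0.02 log units; within the scatter) from compound 1 to compound 2 and an at least 1.3-fold higher number (0.12 log units; that floor lies within the scatter) from compound 3 to compound 4; the limit leaves it open whether they differ. As far as these compounds go, this shows no clear sign that the change behaves differently on the two cores, but it does not show that it carries over unchanged, since the true size of the second step is unknown.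

The compounds shown leave open how either core responds when the sulfonyl sulfur carries something other than these two chlorinated phenyl groups, such as an amine or a carboxylic acid on the ring. They also leave open where compound 4 lies beyond its limit.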